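The compounds below may be only part of what the source reports. "The series", "measured", "known", "first", "only" and "open" are said of these compounds alone.

Compound 1 `CC(=O)NC1=NC(c2ccccc2)CN1` is the reference point of this series. In a functional assay on the whole organism for antagonist activity, with Mus musculus as the target, in the maximal electroshock model (a higher number here means that more compound is needed for the effect, a lower number that less compound is needed), compound 1 gives 54 mg/kg. Compound 2 `CCC(=O)NC1=NC(c2ccccc2)CN1` carries a single alteration against it: methyl in place of hydrogen on a saturated chain carbon bound to a carbonyl carbon. In this assay compound 2 gives 75 mg/kg, so that the alteration produced a 1.4-fold higher number from compound 1 to compound 2 (0.14 log units; within the scatter). Compound 3 `COC(=O)NC1=NC(c2ccccc2Cl)CN1C` rests on a different core; the difference between the two cores is not broken down here. In this assay, among the compounds with values here, compound 3 gives 28 mg/kg, the lowest of the three numbers so far.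

Compound 4 `CCOC(=O)NC1=NC(c2ccccc2Cl)CN1C` has not yet been tested. Compared with compound 3 the alteration is methyl in place of hydrogen on a saturated chain carbon bound to an oxygen next to a carbonyl group. Within the data shown here, this is the same kind of change as the one from compound 1 to compound 2, but not the same: there the methyl entered on a saturated chain carbon bound to a carbonyl carbon, whereas here it enters on a saturated chain carbon bound to an oxygen next to a carbonyl group. Among the compounds shown, this kind of change is seen twice in all.

Among the measured compounds shown here, for compound 4 the expectation is a 1.3-fold higher number from compound 3 to compound 4 (0.11 log units; within the scatter) in this assay, a step of about the size seen from compound 1 to compound 2, because a 1.4-fold higher number from compound 1 to compound 2 (0.14 log units; within the scatter) is the only measured precedent and it stayed within the scatter. Compound 4 is therefore estimated at 36 mg/kg, with a plausible range from 18 mg/kg to 72 mg/kg.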

Compound 4, dose for half-maximal effect: 28 mg/kg
Compound 4: the middle estimate sits 1.3-fold (0.11 log units) above what was measured; the measured number falls inside the stated range.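

In this assay, the extension of methoxycarbonyl to ethoxycarbonyl gave no change at the digits printed from compound 3 to compound 4 (within the scatter). Set beside the earlier step, which put a methyl on a saturated chain carbon bound to a carbonyl carbon, this step shows that the two cores give results that cannot be told apart: the same change on two cores in this assay, a 1.4-fold higher number (0.14 log units; within the scatter) from compound 1 to compound 2 and no change at the digits printed (within the scatter) from compound 3 to compound 4, 1.4-fold (0.14 log units) apart, within the scatter of two such steps This supports only a modest statement, namely that on these two cores the added methyl produced no step beyond the scatter; it does not show that the change would stay this small on any other core, and with only two small steps, at places that are not identical, the agreement does not test whether a larger effect would carry from one core to the other.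

The compounds shown leave open whether the number in this assay would stay where it is with a longer chain, such as propoxycarbonyl or butoxycarbonyl, or with an amine or a carboxylic acid in place of the ethyl group. They also leave open what separates the two cores, since no pair shown crosses from one core to the other with a difference in a single place.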